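Moving the Ring One Bond Out Along the Chain

This account rests on a few compounds, and the source may have more. Where it says the series, first, only, none or still open, it means among the compounds named here.

Compound 1 `COc1cc(/C=C/C(=O)Nc2ccccc2)ccc1OCCCN1CCCC1` gives 1.57 in a physicochemical assay for lipophilicity, using the shake flask method, measured as octanol-water partition, at pH 7.4; a lower number here means a more polar compound, a higher number a more lipophilic compound.
Compound 2 `COc1cc(/C=C/C(=O)Nc2ccccc2)ccc1OCCCCN1CCCCC1` gives 1.61 in this assay.
Compound 3 `COc1cc(/C=C/C(=O)Nc2ccccc2)ccc1OCCCCCN1CCCCC1` gives 1.65 in this assay.

Compound 3 holds the highest of the three numbers, yet a number 0.08 log units higher from compound 1 to compound 3 (within the scatter) and a number 0.04 log units higher from compound 2 to compound 3 (within the scatter) both lie within the scatter, so the three compounds cannot be told apart on this assay. Compound 4 `COc1cc(/C=C/C(=O)Nc2ccccc2)ccc1OCCCCCCN1CCCC1` differs from compound 3 in one place: (pyrrolidin-1-yl)methyl in place of piperidin-1-yl on a saturated chain carbon, five bonds along the chain from an oxygen on an aromatic ring. The earlier steps shown here that bear on this change are a number 0.04 log units higher from compound 1 to compound 2 (within the scatter) and a number 0.04 log units higher from compound 2 to compound 3 (within the scatter), each swapping ring size against chain length without a shift beyond the scatter. The same outcome is expected here, so the estimated step is a number 0.02 log units higher from compound 3 to compound 4 (within the scatter). Compound 4 is therefore expected to give about 1.67, within a range from 1.4 to 1.95.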

Compound 4, partition coefficient: 1.76
The estimate for compound 4 lay 0.09 log units below the measured number; the measured number falls inside the stated range.
By their numbers in this assay, from the lowest: compounds 1, 2, 3 and 4 (each within the scatter of the next).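

In this assay, the step with the ring moved furthest out, a number 0.11 log units higher from compound 3 to compound 4 (within the scatter), is joined by a number 0.15 log units higher from compound 2 to compound 4 (within the scatter) and a number 0.19 log units higher from compound 1 to compound 4 (within the scatter). Even the largest of these steps therefore does not separate the four compounds, so exchanging piperidin-1-yl for (pyrrolidin-1-yl)methyl at this position, five bonds along the chain from the oxygen, leaves the number unresolved. No measurement here offers an explanation for these small differences. Still open, from the compounds shown here alone, is whether an open-chain amine such as diethylamino, or a piperazine ring with its second nitrogen, would give a step beyond the scatter at this chain end.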